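Chain change from compound 2 to compound 4

The source may hold more compounds than are shown below. What is called first, only, known or untested is meant among the compounds shown, and "the series" means these compounds.

Measured in a functional assay on HCC827 cells (Homo sapiens) for inhibition, read by fluorescence, with a stated time of 72 h (a lower number here means a stronger inhibitor of growth, a higher number a weaker inhibitor of growth), so far
compound 1 `COc1ccc(Nc2nc(N[C@H]3CC[C@H](N)CC3)nc3c2ncn3CCC(C)C)c(OC)c1` gives 32900 nM
compound 2 `CC(C)=CCn1cnc2c(Nc3cccc(Cl)c3)nc(N[C@H]3CC[C@H](N)CC3)nc21` gives 13500 nM
compound 3 `COc1cc(Nc2nc(N[C@H]3CC[C@H](N)CC3)nc3c2ncn3CCC(C)C)cc(OC)c1` gives 11200 nM

Compound 2 at 13500 nM lies within the scatter of compound 3 and beyond it from compound 1. The change from compound 2 to compound 4 `CCCCCCn1cnc2c(Nc3cccc(Cl)c3)nc(N[C@H]3CC[C@H](N)CC3)nc21` is pentyl in place of 2-methylprop-1-en-1-yl on a saturated chain carbon bound to an aromatic nitrogen on a saturated chain carbon bound to an aromatic nitrogen. Within the data shown here, the one measured step (a 2.9-fold lower number from compound 1 to compound 3 (0.47 log units; beyond the scatter)) swaps dimethoxyphenyl groups and leaves the chain alone, so it serves only as a gauge of size. Among the measured compounds shown here, no measured pair varies this chain. A step no larger than that modest one, with no settled direction, is expected in this assay and likely stays within the scatter. For compound 4 the estimated value is 11000 nM with an expected range from 3500 nM to 30000 nM in this series. That estimate amounts to an expected 1.2-fold lower number from compound 2 to compound 4 (0.09 log units; within the scatter) and no more.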

Compound 4, concentration for 50% growth inhibition: 10200 nM
Beside the measured number, compound 4's estimate is 1.1-fold (0.03 log units) above it; low and high end bracket the measured number.
By their numbers in this assay, from the lowest: compounds 4, 3 and 2 (each within the scatter of the next); then compound 1.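

In this assay, among these compounds, the first measured change at this chain on the aromatic nitrogen gives a 1.3-fold lower number from compound 2 to compound 4 (0.12 log units; within the scatter), so the two chains cannot be told apart here. Pentyl in place of 2-methylprop-1-en-1-yl removes the double bond outside aromatic rings and adds one carbon, and this combined change gives no readable shift in growth inhibition. No measurement on hand bears on this result.

The two differences are made together, so their separate contributions remain unresolved. Also open, as far as these compounds go, is whether a chain ending in an amine or a carboxylic acid, or a chain longer than hexyl, would separate from compound 4 at this place.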